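Cytotoxicity notes on a shared core with varied aryl substituents

A few compounds are considered here, and "the series" means these few. Any claim that something is new, unique, unknown or untested is made for them only; others in the source may bear on it.

In an ADME assay on HepG2 cells (Homo sapiens) for cytotoxicity, read by luminescence, with a stated time of 72 h (on this read-out lower numbers stand for an effect already at smaller amounts and higher numbers for an effect only at larger amounts of compound), compound 3 `CCOC(=O)c1c(-c2cccc(OC(F)(F)F)c2)[nH]c2cc(OC)ccc2c1=O` gives > 21500 nM, a limit of the assay rather than a number. Compound 1 `C=Cc1cccc(-c2[nH]c3cc(OC)ccc3c(=O)c2C(=O)OCC)c1` gives > 21500 nM, likewise a limit. Compound 2 `CCOC(=O)c1c(-c2cccc(OC(C)C)c2)[nH]c2cc(OC)ccc2c1=O` gives > 21500 nM, also a limit. Thus (the limit of > 21500 nM in this assay, at which 3 of the 3 values shown sit), so compound 3 stands at the same limit as both others, and the steps a step that the two limits leave unreadable from compound 1 to compound 2, a step that the two limits leave unreadable from compound 1 to compound 3 and a step that the two limits leave unreadable from compound 2 to compound 3 cannot be sized. Compound 4 `CCOC(=O)c1c(-c2cccc(S(C)(=O)=O)c2)[nH]c2cc(OC)ccc2c1=O` carries the change (methylsulfonyl in place of trifluoromethoxy on an aromatic carbon). Going by the values given here, no measured step bears readably on this change, so neither direction nor size can be drawn from the three values. Compound 4 is nonetheless expected to stay near the shared limit, with an estimated step that the limit leaves unreadable from compound 3 to compound 4 in this assay. The estimate for compound 4 in this assay is 30000 nM, within the range 12000 nM to 80000 nM.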

Compound 4, half-maximal effective concentration: > 21500 nM
Compound 4 ended at the assay's limit; the forecaster's own chance of this, stated with the estimate: 85%; the middle value lies beyond the limit too.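

The steps from compound 1, compound 2 and compound 3 to compound 4 cannot be read, as each value is a limit and not a number: the limit of > 21500 nM in this assay, at which 4 of the 4 values shown sit. As far as these compounds go, whether any of these aryl substituents shifts the read-out in this assay stays open.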